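A methyl added to compound 3's methylamino group

A few compounds are considered here, and "the series" means these few. Any claim that something is new, unique, unknown or untested is made for them only; others in the source may bear on it.

Measured so far in a functional assay on SW480 cells (Homo sapiens) for antiproliferative activity, read by MTT assay, with a stated time of 48 h; a lower number here means a stronger inhibitor, a higher number a weaker inhibitor:
- Compound 1 `CCCCCCC(CCO)n1cnc2c(N(C)C)ncnc21`: > 50000 nM (a limit of the assay)
- Compound 2 `CCCCCCCCC(CCO)n1cnc2c(OC)ncnc21`: 24600 nM
- Compound 3 `CCCCCCCCC(CCO)n1cnc2c(NC)ncnc21`: 3770 nM

Compound 3 holds the lower of the two true numbers in this assay, and the third result is only a limit. The next compound, compound 4 `CCCCCCCCC(CCO)n1cnc2c(N(C)C)ncnc21`, takes methyl in place of hydrogen on a nitrogen on an aromatic ring, turning methylamino into dimethylamino: methyl in place of hydrogen on a nitrogen on an aromatic ring.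

Among the measured compounds shown here, one measured step bears on this place. It is a 6.5-fold lower number from compound 2 to compound 3 (0.81 log units; beyond the scatter), and it shows that the group at this position can move the number beyond the scatter. That step swaps methoxy for methylamino, though, so it does not measure the added methyl directly.

Compound 1 also carries dimethylamino. Compound 1 reads > 50000 nM, which is a limit. For the measured compounds named here, this is the only result for that group, and it gives no number to work from.

With so little to go on, a modest move towards a weaker inhibitor is expected, and the estimated step is a 2.1-fold higher number from compound 3 to compound 4 (0.33 log units; beyond the scatter). For compound 4 the estimated value is 8000 nM, with an expected range from 2500 nM to 30000 nM.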

Compound 4, half-maximal inhibitory concentration: 21600 nM
Estimate against measurement, compound 4: 2.7-fold (0.43 log units) below; measured number inside the range.
By their numbers in this assay, from the lowest: compound 3; then compounds 4 and 2 (each within the scatter of the next). At a limit, above all of these: compound 1.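

In this assay the added methyl now has a measure of its own, a 5.7-fold higher number from compound 3 to compound 4 (0.76 log units; beyond the scatter), which the earlier swap of methoxy for methylamino could not give, and it shows that replacing the last hydrogen on this nitrogen costs about as much as that swap gained. Dimethylamino and methoxy cannot be told apart here, with a 1.1-fold lower number from compound 2 to compound 4 (0.06 log units; within the scatter), so among these three groups the lower number belongs to methylamino alone and not to any nitrogen placed at this position. With dimethylamino held fixed, ethyl in place of hydrogen on the chain gives an at least 2.3-fold lower number from compound 1 to compound 4 (0.36 log units; beyond the scatter), a step read from the limit of compound 1: the limit of > 50000 nM in this assay, at which 1 of the 4 values shown sits.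

Going by these compounds, whether the plain amino group or a larger group on this nitrogen, such as ethylamino, would read with compound 3 or with compound 4 remains open. On these data alone, the true number of compound 1 also remains open, and with it the full size of the step that the ethyl makes on the chain.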